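A few compounds are considered here, and "the series" means these few. Any claim that something is new, unique, unknown or untested is made for them only; others in the source may bear on it.

In a functional assay on PC-3 cells (Homo sapiens) for cytotoxicity, read by resazurin assay, with a stated time of 48 h (a lower number here means a stronger inhibitor, a higher number a weaker inhibitor), compound 1 `C=C(C)[C@@H]1CC=C(CN(OC)C2O[C@@H](CO)[C@H](N=[N+]=[N-])[C@@H](O)[C@@H]2O)CC1` gives 263000 nM, compound 2 `C=C(C)[C@@H]1CC=C(CN(OC)C2O[C@H](CN=[N+]=[N-])[C@@H](N=[N+]=[N-])[C@H](O)[C@H]2O)CC1` gives 57000 nM and compound 3 `C=C(C)[C@@H]1CC=C(CN(OC)C2O[C@H](CO)[C@@H](O)[C@H](O)[C@H]2N=[N+]=[N-])CC1` gives 176000 nM. Compound 3 thus lies within the usual scatter of compound 1, while compound 2 shows a lower number than compound 3 by more than the scatter, marking it as the stronger inhibitor of that pair. Compound 4 `C=CCOC(=O)N[C@H]1C(N(CC2=CC[C@@H](C(=C)C)CC2)OC)O[C@H](CO)[C@@H](O)[C@@H]1O` has (allyloxycarbonyl)amino in place of azido on a saturated ring carbon of compound 3: (allyloxycarbonyl)amino in place of azido on a saturated ring carbon. Among the compounds with values here, no measured pair shows this swap on its own, so a small step, within the scatter, is expected, towards a slightly lower number. The estimated change is a 1.4-fold lower number from compound 3 to compound 4 (0.13 log units; within the scatter). For compound 4, the expected value is 130000 nM, with an estimated range from 50000 nM to 300000 nM.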

Compound 4, half-maximal inhibitory concentration: 826000 nM
For compound 4 the middle estimate is 6.4-fold (0.80 log units) below the measured one; the measured number lies above the stated range.
By their numbers in this assay, from the lowest: compound 2; then compounds 3 and 1 (each within the scatter of the next); then compound 4.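

Within the data shown here, this is the first step between measured compounds that differ in one place: in this assay, (allyloxycarbonyl)amino in place of azido on this saturated ring carbon gives a 4.7-fold higher number from compound 3 to compound 4 (0.67 log units; beyond the scatter), which is beyond the scatter. The change at this position therefore weakens the compound, rather than leaving it about level. No measured evidence here gives a reason for the loss. Still open, going by these compounds, is how a free amine or a plain acetamide on this carbon would compare, and so whether the allyl part of the new group goes with the loss.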